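Replacing the pyrimidin-2-yl of compound 3 with an acyclic oxime ether

The source may hold more compounds than are shown below. What is called first, only, known or untested is meant among the compounds shown, and "the series" means these compounds.

Measured so far in a functional assay for activation of Alpha-1B adrenergic receptor (Homo sapiens), read by calcium flux; on this read-out lower numbers stand for an effect already at smaller amounts and higher numbers for an effect only at larger amounts of compound:
compound 1 `c1csc(-c2ccccc2NCC2=NCCN2)c1` gives 5.75 nM
compound 2 `Cc1noc(-c2ccccc2NCC2=NCCN2)n1` gives < 5020 nM
compound 3 `c1cnc(-c2ccccc2NCC2=NCCN2)nc1` gives 77.6 nM

The value of compound 2 is a limit of this assay, not a number. Among the two numbers, compound 3 has the higher one; the step of a 13-fold higher number from compound 1 to compound 3 (1.13 log units; beyond the scatter) is the only readable step in the set, the steps a step that the limit leaves unreadable from compound 1 to compound 2 and a step that the limit leaves unreadable from compound 2 to compound 3 being unreadable through the limit (the limit of < 5020 nM in this assay, at which 1 of the 3 values shown sits).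

Compound 4 `CCO/N=C(\C)c1ccccc1NCC1=NCCN1` is not yet measured. It differs from compound 3 by a group of 6 heavy atoms (4 carbon, 1 nitrogen, 1 oxygen; no ring) in place of a group of 6 heavy atoms (4 carbon, 2 nitrogen; one six-membered aromatic ring with 2 hetero atoms), on an aromatic carbon: a group without ring enters where every measured compound carries an aromatic ring. For the measured compounds named here, no measured step concerns a change of this kind; the one readable step, from thiophen-2-yl to pyrimidin-2-yl, only shows that the group on this carbon can shift the number by a large amount. The expectation for compound 4 therefore carries wide uncertainty; a step of a 3.9-fold higher number from compound 3 to compound 4 (0.59 log units; beyond the scatter) toward a higher number is estimated, with the possibility that only a limit is returned. The estimate for compound 4 in this assay is 300 nM, with a range from 40 nM to 3000 nM.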

Compound 4, half-maximal effective concentration: < 5020 nM
Compound 4 ended at the assay's limit; the forecaster's own chance of this, stated with the estimate: 25%; the middle value lies beyond the limit too.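

In this assay compound 4 gives < 5020 nM, which is a limit and not a number. The steps to compound 4 from compound 1, compound 2 and compound 3 therefore cannot be read: the limit of < 5020 nM in this assay, at which 2 of the 4 values shown sit.

The compounds shown leave open how far the acyclic oxime ether of compound 4 stands from the pyrimidin-2-yl of compound 3, and whether compound 2 and compound 4 differ at all.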